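This account rests on a few compounds, and the source may have more. Where it says the series, first, only, none or still open, it means among the compounds named here.

Compounds measured in a functional assay on MCF7 cells (Homo sapiens) for antiproliferative activity, read by MTT assay, with a stated time of 72 h; on this read-out higher numbers stand for weaker inhibition and lower numbers for stronger inhibition:
compound 1 `O=c1[nH]c(=O)n(CCC(CO)CO)cc1-c1cccs1`, 6000 nM;
compound 2 `O=c1[nH]c(=O)n(CCC(CO)CO)cc1C#CC1CC1`, > 100000 nM, which is a limit of the assay and not a number.

Compound 2 thus stands at the limit of > 100000 nM in this assay, at which 1 of the 2 values shown sits, with no number resolved. Compound 3 `O=c1[nH]c(=O)n(CCC(CO)CO)cc1C#CCCCCl` differs from compound 2 in one place: 3-chloropropyl in place of cyclopropyl on a triple-bonded carbon. Among the compounds with values here, the only measured step, an at least 16-fold higher number from compound 1 to compound 2 (1.22 log units; beyond the scatter), altered the group on the aromatic carbon, not the group on the triple-bonded carbon, so it gives no direct guide here. With compound 2 already at the limit, compound 3 is expected to remain near it, an expected step of a number no higher from compound 2 to compound 3 (the limit leaves the size open). The estimate for compound 3 in this assay is 100000 nM, within 30000 nM to 300000 nM.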

Compound 3, half-maximal inhibitory concentration: 35200 nM
Beside the measured number, compound 3's estimate is 2.8-fold (0.45 log units) above it; the measured number falls inside the stated range.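

In this assay, the group on the triple-bonded carbon can move the read-out: 3-chloropropyl in place of cyclopropyl gives an at least 2.8-fold lower number from compound 2 to compound 3 (0.45 log units; beyond the scatter), so a triple-bonded substituent at this place can yield a resolved number. As far as these compounds go, the value of compound 2 remains a limit and not a number, so the true size of this step is unknown. Thiophen-2-yl nevertheless keeps the lower number, with a 5.9-fold higher number from compound 1 to compound 3 (0.77 log units; beyond the scatter).

The compounds shown leave open whether the chlorine or the open chain accounts for the step. A plain propyl group, or an amine in place of the chlorine, would help separate the two.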